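The source may hold more compounds than are shown below. What is called first, only, known or untested is meant among the compounds shown, and "the series" means these compounds.

Series notes, step from compound 3 to compound 4.

Compound 3 `Cc1nn(-c2ncnc3nc[nH]c23)c2c1C(OCc1ccc(C(C)C)cc1)CC(=O)N2` sits at the low end of the three numbers measured in a functional assay on HEK293 cells for agonist activity at G-protein coupled receptor 39 (Homo sapiens), read by scintillation proximity assay and inositol phosphate accumulation, with a stated time of 75 min, in the presence of a further agent that is not named here (a lower number here means that less compound is needed, a higher number that more compound is needed for the effect), where compound 3 gives 5 nM. Compound 2 `Cc1nn(-c2ncnc3nc[nH]c23)c2c1C(OCc1ccccc1C#N)CC(=O)N2` gives 8 nM; the change a 1.6-fold lower number from compound 2 to compound 3 (0.20 log units; within the scatter) is within the scatter, so the two cannot be ordered. Going by the values given here, compound 1 `C/C(=N\NC(=O)c1cc2ccccc2cc1O)c1ccc(N)cc1` has a different core and gives 1100 nM; the two values show compound 1 far higher than compound 3, and no single-point step connects them.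

Compound 4 `Cc1nn(-c2ncnc3nc[nH]c23)c2c1C(OCc1ccc(F)cc1)CC(=O)N2` differs from compound 3 by fluoro in place of isopropyl on an aromatic carbon. Among the compounds with values here, the only measured step that bears on this position is the change of the aryl group on the benzylic carbon, a 1.6-fold lower number from compound 2 to compound 3 (0.20 log units; within the scatter), which stayed within the scatter. On that basis no step beyond the scatter is expected in this assay. The estimated step, a 1.6-fold higher number from compound 3 to compound 4 (0.20 log units; within the scatter), is accordingly expected to be small. Compound 4 is therefore estimated at 8 nM, with a range from 3 nM to 25 nM.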

Compound 4, half-maximal effective concentration: 1 nM
For compound 4 the middle estimate is 8.0-fold (0.90 log units) above the measured one; the measured number lies below the stated range.
By their numbers in this assay, from the lowest: compound 4; then compounds 3 and 2 (each within the scatter of the next); then compound 1.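

In this assay, the group on this aromatic carbon, para to a large group, now makes a difference: a 5.0-fold lower number from compound 3 to compound 4 (0.70 log units; beyond the scatter) is beyond the scatter, whereas the earlier aryl change, a 1.6-fold lower number from compound 2 to compound 3 (0.20 log units; within the scatter), did not separate its two compounds. The 4-fluorophenyl group also separates from the 2-cyanophenyl group, with an 8.0-fold lower number from compound 2 to compound 4 (0.90 log units; beyond the scatter) likewise beyond the scatter, so compound 4 stands apart from both close analogues, while compounds 2 and 3 remain unordered. Nothing in the data shown accounts for these steps.

From the compounds shown here alone, with only isopropyl and fluoro compared at this place, it remains open whether the step tracks the number of heavy atoms or is particular to fluoro. Groups such as chloro, methoxy, an amine or a carboxylic acid at this place would show whether the lower number extends beyond compound 4.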